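This account rests on a few compounds, and the source may have more. Where it says the series, first, only, none or still open, it means among the compounds named here.

Measured so far in a functional assay on A549 cells (Homo sapiens) for antiproliferative activity, with a stated time of 5 days (on this read-out lower numbers stand for stronger inhibition and higher numbers for weaker inhibition), are these compounds:
compound 1 `O=C1C=CC2(C=C1)OCC(=O)N2c1nc(-c2ccc3c(c2)OCCO3)nn1-c1ccccc1` at 170 nM
compound 2 `O=C1C=CC2(C=C1)OCC(=O)N2c1nc(-c2ccc(F)c3ccccc23)nn1-c1ccccc1` at 320 nM
compound 3 `O=C1C=CC2(C=C1)OCC(=O)N2c1nc(-c2ccc3ccccc3c2)nn1-c1ccc(C(F)(F)F)cc1` at 460 nM

The value of compound 2 lies within the usual scatter of the values of both compound 1 and compound 3, so it cannot be separated from either. The next compound to be tested is compound 4 `O=C1C=CC2(C=C1)OCC(=O)N2c1nc(-c2cccc(Cl)c2)nn1-c1ccccc1`, which differs from compound 2 as follows: 3-chlorophenyl in place of 4-fluoronaphthalen-1-yl on an aromatic carbon. Here 3-chlorophenyl stands in place of 4-fluoronaphthalen-1-yl on an aromatic carbon of the five-membered aromatic ring.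

Going by the values given here, only one measured step changes a group on an aromatic carbon, a 1.9-fold higher number from compound 1 to compound 2 (0.27 log units; within the scatter), and it stays within the scatter. Among the compounds with values here, no tested compound carries 3-chlorophenyl, so this single step is thin support. Even so, the data give no reason to expect a shift beyond the scatter in this assay in either direction. The estimated 1.1-fold lower number from compound 2 to compound 4 (0.03 log units; within the scatter) is accordingly small. For compound 4 the expected value is 300 nM in an estimated range from 120 nM to 750 nM for repeated measurements.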

Compound 4, half-maximal inhibitory concentration: 25.2 nM
The estimate for compound 4 lay 12-fold (1.08 log units) above the measured number; measured number outside the range, below it.
By their numbers in this assay, from the lowest: compound 4; then compounds 1, 2 and 3 (each within the scatter of the next, the first and the last beyond it).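

In this assay, going by these compounds alone, this aromatic carbon, between two ring nitrogen atoms, proved able to move the read-out well beyond the scatter: the change to 3-chlorophenyl gives a 13-fold lower number from compound 2 to compound 4 (1.10 log units; beyond the scatter), and from the benzodioxin-bearing compound it gives a 6.7-fold lower number from compound 1 to compound 4 (0.83 log units; beyond the scatter), whereas the one earlier step at this place stayed within the scatter. Among compounds 1, 2 and 4, which differ only at this carbon, compound 4 has the lowest number, so a larger group with two six-membered aromatic rings of carbon is not needed here. Nothing measured on these groups explains the size of this drop.

The compounds shown leave open whether the chlorine matters or the single ring alone suffices, which an unsubstituted phenyl or a 3-methoxyphenyl at this carbon would address. Also open, on these data alone, is whether 3-chlorophenyl keeps this effect when a pyridine ring replaces the phenyl group on the neighbouring ring atom that bears it.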